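Swapping the Side Arm: Expected Cytotoxicity of Compound 3

The compounds below may be only part of what the source reports. "The series", "measured", "known", "first", "only" and "open" are said of these compounds alone.

The compounds here share one core, carrying an amine nitrogen that bears two side arms. Compound 1 `Cc1ccc2[nH]c(=O)c(CN(Cc3ccc(OCC(=O)O)cc3)Cc3ccc(C(C)(C)C)cc3)cc2c1` is one of them. In a toxicity assay on MDCK cells (Canis lupus familiaris) for cytotoxicity, read by crystal violet staining, with a stated time of 48 h (on this read-out higher numbers stand for lower toxicity in this test and lower numbers for higher toxicity in this test), compound 1 reaches only the limit of > 10000 nM, which is a limit of the test rather than a number. Compound 2 `Cc1ccc2[nH]c(=O)c(CN(Cc3ccc(C(C)(C)C)cc3)[C@H](CO)c3ccccc3)cc2c1` carries a 2-hydroxy-1-phenylethyl group on the amine nitrogen in place of the 4-(carboxymethoxy)benzyl group. In this assay compound 2 likewise reaches only the limit of > 10000 nM. The step that the two limits leave unreadable from compound 1 to compound 2 therefore cannot be read in size; all that stands is the limit of > 10000 nM in this assay, at which 2 of the 2 values shown sit. Compound 3 `COc1ccc(C(C)N(Cc2ccc(C(C)(C)C)cc2)Cc2cc3cc(C)ccc3[nH]c2=O)cc1` is not yet measured. It differs from compound 2 by 1-(4-methoxyphenyl)ethyl in place of 2-hydroxy-1-phenylethyl on an amine nitrogen. Within the data shown here, no measured step shows a direction for this exchange, and the only evidence is the limit of > 10000 nM in this assay, at which 2 of the 2 values shown sit, so the expectation is no step beyond the scatter in this assay, with compound 3 again most likely sitting at the limit. On that basis, compound 3 is expected to show 15000 nM, between 5000 nM and 50000 nM. The step that the limit leaves unreadable from compound 2 to compound 3 is thus expected to be essentially flat.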

Compound 3, half-maximal cytotoxic concentration: > 5000 nM
Compound 3 gave a limit, no number (the forecaster's own chance of this, stated with the estimate: 80%); the middle value does not contradict the limit.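

In this assay compound 3 gives > 5000 nM, which is a limit of the test and not a number. Among these compounds, compound 1 and compound 2 also stand only at limits, so no step to compound 3 can be read from either. The compounds shown leave open whether exchanging a side arm on the amine nitrogen changes cytotoxicity at all.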